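The compounds below may be only part of what the source reports. "The series", "measured", "known", "first", "only" and "open" are said of these compounds alone.

Going by the values given here, in a functional assay on MCF7 cells (Homo sapiens) for inhibition, read by MTT assay, with a stated time of 72 h (on this read-out lower numbers stand for stronger inhibition and higher numbers for weaker inhibition), compound 1 (`O=[N+]([O-])c1ccc(-c2nnc(SCCCN3CCN(c4nc5ccccc5o4)CC3)o2)cc1`) gives 90100 nM and compound 2 (`O=[N+]([O-])c1ccc(-c2nnc(SCCCN3CCN(c4nc5ccccc5s4)CC3)o2)cc1`) gives 118000 nM as the only two measurements so far. The measured step is a 1.3-fold higher number from compound 1 to compound 2 (0.12 log units; within the scatter) and it places 1,3-benzothiazol-2-yl in place of 1,3-benzoxazol-2-yl on an amine nitrogen in a ring. Compound 2 therefore stands level with compound 1, and the two cannot be told apart on these numbers.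

Compound 3 (`Brc1ccc(-c2nnc(SCCCN3CCN(c4nc5ccccc5s4)CC3)o2)cc1`) differs from compound 2 in one place (bromo in place of nitro on an aromatic carbon): bromo in place of nitro on an aromatic carbon, para to a large group, so that 4-nitrophenyl becomes 4-bromophenyl. Among the compounds with values here, no measured step covers this swap, and the one step available concerns a different part of the molecule. Compound 2 at 118000 nM is thus the anchor for the expectation, and no step beyond the scatter is expected in this assay in either direction. Within the data shown here, the estimate amounts to a 1.2-fold lower number from compound 2 to compound 3 (0.07 log units; within the scatter) as the expected result, with a wide margin for a swap that has no measured precedent. For compound 3 the estimated value is 100000 nM with an expected range from 40000 nM to 250000 nM on this read-out.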

Compound 3, half-maximal inhibitory concentration: 96300 nM
Compound 3: the middle estimate sits 1.0-fold (0.02 log units) above what was measured; measured number inside the range.
By their numbers in this assay, from the lowest: compounds 1, 3 and 2 (each within the scatter of the next).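

In this assay, the change from nitro to bromo on the aromatic carbon gives a 1.2-fold lower number from compound 2 to compound 3 (0.09 log units; within the scatter), so 4-bromophenyl and 4-nitrophenyl cannot be told apart on these numbers. Going by these compounds alone, the earlier step concerned only the group on the amine nitrogen in a ring, so this is the first measured look at the aromatic ring that carries nitro or bromo, and here a group with hydrogen-bond acceptors gives way to a single bromine atom, which has none, without a step beyond the scatter. There is no evidence here that explains this result.

As far as these compounds go, both measured steps lie within the scatter, so it remains open whether any change at either place can move the number beyond it, and two groups on this aromatic carbon say little about the full range of what could sit there. An amine or a carboxylic acid on the same aromatic carbon would test this position further, and a longer chain in place of the one that carries the sulfur would probe another part of the molecule.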